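This account rests on a few compounds, and the source may have more. Where it says the series, first, only, none or still open, it means among the compounds named here.

Measured compounds:

Compound 1, `CCn1nc(-c2ccnc(Nc3ccc(S(N)(=O)=O)cc3)n2)c2ccccc21`: 2280 nM
Compound 2, `CCn1nc(-c2ccnc(Nc3ccc(O)cc3)n2)c2ccccc21`: 5780 nM
Compound 3, `CCCn1nc(-c2ccnc(Nc3ccc(O)cc3)n2)c2ccccc21`: 3340 nM

All three were tested in a functional assay on MCF7 cells (Homo sapiens) for antiproliferative activity, read by MTT assay, with a stated time of 72 h; on this read-out lower numbers stand for stronger inhibition of growth and higher numbers for weaker inhibition of growth. Compound 2 gives 5780 nM, and compound 1 gives 2280 nM. These two share a core and differ only by sulfamoyl in place of hydroxy on an aromatic carbon; that change yields a 2.5-fold lower number from compound 2 to compound 1 (0.40 log units; beyond the scatter). Compound 3 gives 3340 nM; it differs from compound 2 by methyl in place of hydrogen on a saturated chain carbon, two bonds along the chain from an aromatic nitrogen, a change that yields a 1.7-fold lower number from compound 2 to compound 3 (0.24 log units; within the scatter), so compounds 2 and 3 cannot be ordered against each other.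

Compound 4, `CCCn1nc(-c2ccnc(Nc3ccc(S(N)(=O)=O)cc3)n2)c2ccccc21`, has not yet been measured in this assay. It differs from compound 3 by sulfamoyl in place of hydroxy on an aromatic carbon, placed as it is in compound 1. Since the surroundings of the change are described in the same words for both pairs, this is the same change made once more on a core that differs from that of compound 2 by methyl in place of hydrogen on a saturated chain carbon, two bonds along the chain from an aromatic nitrogen. Among the compounds shown it occurs twice in all, once measured and once pending.

Because the measured instance gave a 2.5-fold lower number from compound 2 to compound 1 (0.40 log units; beyond the scatter), compound 4 is expected to show a step of a 2.4-fold lower number from compound 3 to compound 4 (0.38 log units; beyond the scatter) relative to compound 3. On that basis compound 4 is estimated at 1400 nM, with a likely range from 600 nM to 3500 nM.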

Compound 4, concentration for 50% growth inhibition: 590 nM
Estimate against measurement, compound 4: 2.4-fold (0.38 log units) above, and the stated range ends above it.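

In this assay, sulfamoyl in place of hydroxy on the core of compound 3 gives a 5.7-fold lower number from compound 3 to compound 4 (0.75 log units; beyond the scatter), which points the same way as the earlier instance of this change, and the two steps cannot be told apart: the same change on two cores in this assay, a 2.5-fold lower number (0.40 log units; beyond the scatter) from compound 2 to compound 1 and a 5.7-fold lower number (0.75 log units; beyond the scatter) from compound 3 to compound 4, 2.2-fold (0.35 log units) apart, within the scatter of two such steps. Methyl in place of hydrogen on the chain carbon, read on the sulfamoyl pair, gives a 3.9-fold lower number from compound 1 to compound 4 (0.59 log units; beyond the scatter), which lies beyond the scatter, whereas the same change on the hydroxy pair lay within it, yet these two steps cannot be told apart either: the same change on two cores in this assay, a 1.7-fold lower number (0.24 log units; within the scatter) from compound 2 to compound 3 and a 3.9-fold lower number (0.59 log units; beyond the scatter) from compound 1 to compound 4, 2.2-fold (0.35 log units) apart, within the scatter of two such steps. The sulfamoyl change therefore carried from one core to the other in direction, and a single common size fits both instances, but the larger number on the core of compound 3 does not show that the two changes reinforce each other, and two cores do not show that the step holds across the series.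

The compounds shown leave open whether the sulfamoyl step persists with a longer chain on the aromatic nitrogen, and how an amine or a carboxylic acid would compare on the same aromatic carbon. They also leave open whether the order seen here holds in any other cell line.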